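The source may hold more compounds than are shown below. What is called first, only, known or untested is meant among the compounds shown, and "the series" means these compounds.

Measured compounds:
Compound 1 `CC1(OC(=O)N2CCC(O[C@H]3CC[C@H](Oc4cnc(S(C)(=O)=O)cn4)CC3)CC2)CC1` — 25.9 nM
Compound 2 `CS(=O)(=O)c1cnc(O[C@H]2CC[C@H](OC3CCN(C(=O)C4(C(F)(F)F)CC4)CC3)CC2)cn1` — 107 nM

Both compounds share one core and were tested in a functional assay on isolated protein for agonist activity at Glucose-dependent insulinotropic receptor (Homo sapiens), read by HTRF and cAMP accumulation; on this read-out lower numbers stand for an effect already at smaller amounts and higher numbers for an effect only at larger amounts of compound. Compound 1 gives 25.9 nM, and compound 2, where the group on the carbonyl carbon is exchanged, gives 107 nM; that exchange is a 4.1-fold higher number from compound 1 to compound 2 (0.62 log units; beyond the scatter). Compound 2 therefore has the higher of the two numbers shown, with compound 1 as its only point of comparison.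

Compound 3 `CS(=O)(=O)c1cnc(O[C@H]2CC[C@H](OC3CCN(CC4(C(F)(F)F)CC4)CC3)CC2)cn1` takes a different route: (1-(trifluoromethyl)cyclopropyl)methyl in place of (1-(trifluoromethyl)cyclopropyl)carbonyl on an amine nitrogen in a ring. This removes the carbonyl and leaves the ring nitrogen carrying a methyl-linked group instead of an amide. Within the data shown here, no measured step covers this kind of change; the single step known concerns the group beyond the carbonyl, not the carbonyl itself, so it gives only a weak guide. With that in mind, the step from compound 2 to compound 3 in this assay is expected to be small, a 1.9-fold higher number from compound 2 to compound 3 (0.27 log units; within the scatter), with wide uncertainty in either direction. Compound 3 is thus estimated at 200 nM, within a range of 50 nM to 1000 nM.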

Compound 3, half-maximal effective concentration: 62.6 nM
For compound 3 the middle estimate is 3.2-fold (0.50 log units) above the measured one; the range from low to high includes it.
By their numbers in this assay, from the lowest: compound 1; then compounds 3 and 2 (each within the scatter of the next).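

In this assay, (1-(trifluoromethyl)cyclopropyl)methyl in place of (1-(trifluoromethyl)cyclopropyl)carbonyl on the ring nitrogen gives a 1.7-fold lower number from compound 2 to compound 3 (0.23 log units; within the scatter), so in this pair the carbonyl can be absent without a difference that this measurement can resolve. Compound 3 also adds a new kind of comparison, since both earlier compounds carry a carbonyl on this nitrogen, and the ((1-methylcyclopropyl)oxy)carbonyl group of compound 1 still keeps an edge over the carbonyl-free group, with a 2.4-fold higher number from compound 1 to compound 3 (0.38 log units; beyond the scatter), a modest step beyond the scatter. Nothing measured here explains either of these results.

The compounds shown leave open how much of the result depends on the trifluoromethyl group, which a plain cyclopropylmethyl or a 1-methylcyclopropylmethyl on the same nitrogen would test directly. They also leave open whether other links on this nitrogen, such as a sulfonyl or a urea, would fit this pattern or break it, and whether the ((1-methylcyclopropyl)oxy)carbonyl group would keep its edge over them.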